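A few compounds are considered here, and "the series" means these few. Any claim that something is new, unique, unknown or untested is made for them only; others in the source may bear on it.

Compound 1 `CC(=O)N1CC(CC(=O)NO)(NS(=O)(=O)c2ccc(OCc3cc(C)nc4ccccc34)cc2)C1`: < 5 uL/min in an ADME assay on cells (Hepatocyte, Homo sapiens) for metabolic stability, read by LC-MS, tested at 1 uM (a lower number here means slower removal, a higher number faster removal of the compound), a value that is a limit of the assay and not a number.
Compound 2 `Cc1cc(COc2ccc(S(=O)(=O)N(C)C3(C(=O)NO)CN(C(=O)C(C)C)C3)cc2)c2ccccc2n1`: 8 uL/min in this assay.

Compound 2 stands as the only one of the two measured compounds with a true number in this assay; the other value shown is the limit of < 5 uL/min in this assay, at which 1 of the 2 values shown sits. Compound 3 `COCCN(C1(C(=O)NO)CN(C(=O)C(C)C)C1)S(=O)(=O)c1ccc(OCc2cc(C)nc3ccccc23)cc1` has not yet been measured in this assay. It differs from compound 2 in a single place: methoxymethyl in place of hydrogen on a saturated chain carbon bound to a sulfonamide nitrogen. For the measured compounds named here, no step between measured compounds can be read here, as compound 1 gives only a limit. From the structural change alone, a modest step toward faster removal is expected, one that may well stay within the usual scatter of repeated measurements. The step from compound 2 to compound 3 is expected to be a 1.5-fold higher number from compound 2 to compound 3 (0.18 log units; within the scatter). Compound 3 is therefore estimated at 12 uL/min, with a range from 5 uL/min to 30 uL/min.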

Compound 3, intrinsic clearance in a liver preparation (reported as CLH), per the amount of preparation that the assay uses in the Hepatocyte assay: 18 uL/min
Compound 3: middle estimate off by 1.5-fold (0.18 log units), on the low side, within the range that was stated.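

For the compounds shown here, in the Hepatocyte assay the change of methyl to 2-methoxyethyl gives a 2.3-fold higher number from compound 2 to compound 3 (0.35 log units; beyond the scatter), the first step that can be read between two true numbers, and it places this position among those where a change registers in removal. In a physicochemical assay for solubility, with a stated time of 24 h, tested at 30 mg/mL (on this read-out higher numbers stand for higher solubility and lower numbers for lower solubility), compound 2 gives 56000000 nM and compound 3 gives 8900000 nM, a gap beyond the scatter, so the same single change moves this pair on a second read-out as well. Going by these compounds alone, in the Hepatocyte assay compound 1 gives < 5 uL/min, a limit of the assay and not a number, so no step to it can be read.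

This one pair leaves open whether the ether oxygen or the chain itself carries these steps. A plain propyl chain, or a chain ending in an amine or a carboxylic acid, at the same place would bear on that question.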